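A Two-Ring Group on the Sulfonyl Sulfur

A few compounds are considered here, and "the series" means these few. Any claim that something is new, unique, unknown or untested is made for them only; others in the source may bear on it.

In a functional assay on A2780 cells (Homo sapiens) for antiproliferative activity, read by sulforhodamine B assay, with a stated time of 72 h (on this read-out lower numbers stand for stronger inhibition and higher numbers for weaker inhibition), compound 1 (`C[C@@H]1CN(S(=O)(=O)c2ccc(NC(=O)NCc3cccnc3)cc2)C[C@H](C)O1`) gives 15 nM and compound 2 (`C[C@@H]1COC[C@@H](C)N1S(=O)(=O)c1ccc(NC(=O)NCc2cccnc2)cc1`) gives 745 nM as the higher of the two numbers. Compound 3 (`O=C(NCc1cccnc1)Nc1ccc(S(=O)(=O)N2C3CCC2COC3)cc1`) is unmeasured and carries a group of 8 heavy atoms (6 carbon, 1 nitrogen, 1 oxygen; one five-membered non-aromatic ring with 1 hetero atom, one six-membered non-aromatic ring with 2 hetero atoms) in place of a group of 8 heavy atoms (6 carbon, 1 nitrogen, 1 oxygen; one six-membered non-aromatic ring with 2 hetero atoms), on a sulfonyl sulfur in place of the group of compound 2. Among the measured compounds shown here, one measured step bears on this place: a 50-fold higher number from compound 1 to compound 2 (1.70 log units; beyond the scatter) shows that a change here can be large, yet no measured compound carries the new group. Staying near compound 2 is therefore expected, with a 1.9-fold lower number from compound 2 to compound 3 (0.27 log units; within the scatter) as the estimated step and none expected beyond the scatter. Compound 3 is estimated at 400 nM with a range from 80 nM to 1800 nM as expected.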

Compound 3, half-maximal inhibitory concentration: 251 nM
Compound 3: middle estimate off by 1.6-fold (0.20 log units), on the high side, and the stated range covers the measured number.
By their numbers in this assay, from the lowest: compound 1; then compound 3; then compound 2.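

In this assay, the two-ring group on the sulfonyl sulfur gives a 3.0-fold lower number from compound 2 to compound 3 (0.47 log units; beyond the scatter), but it falls short of 2,6-dimethylmorpholin-4-yl, with a 17-fold higher number from compound 1 to compound 3 (1.22 log units; beyond the scatter). All three groups have 8 heavy atoms of the same kinds, so this place separates groups that this count does not tell apart, and compound 1 remains the lowest of the three. Nothing measured here explains these differences. The compounds shown leave open where an unsubstituted morpholin-4-yl, a piperidin-1-yl or a piperazin-1-yl on the sulfonyl sulfur would fall.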